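The source may hold more compounds than are shown below. What is called first, only, known or untested is meant among the compounds shown, and "the series" means these compounds.

Working notes on the series, read in a functional assay on HCT-116 cells (Homo sapiens) for inhibition, read by MTT assay, with a stated time of 72 h; on this read-out higher numbers stand for weaker inhibition and lower numbers for stronger inhibition. Within the data shown here, compound 1 `COc1ccc(CCCNCc2c(OC)cc(Oc3cccc(Nc4ccccc4)c3)cc2OC)cc1` gives 2850 nM, and compound 2 `COc1cc(Oc2cccc(Nc3ccccc3)c2)cc(OC)c1CN(C)C` gives 12900 nM, the higher of the two numbers so far. Among the measured compounds shown here, the one measured step is a 4.5-fold higher number from compound 1 to compound 2 (0.66 log units; beyond the scatter), with dimethylamino in place of (3-(4-methoxyphenyl)propyl)amino on a saturated chain carbon bound to an aromatic carbon.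

For the measured compounds named here, compound 3 `COc1cc(Oc2cccc(Nc3ccccc3)c2)cc(OC)c1CNC1CC1` has no measurement yet. It carries cyclopropylamino in place of dimethylamino on that same saturated chain carbon bound to an aromatic carbon: cyclopropylamino in place of dimethylamino on a saturated chain carbon bound to an aromatic carbon. Going by the values given here, the only step bearing on this change is the modest one above, and it involves a different entering group, so it sets a loose scale and no firm direction. A single step shows no pattern. Any lean toward a lower number rests on compound 1 at 2850 nM alone.

The expected step is a 1.4-fold lower number from compound 2 to compound 3 (0.16 log units; within the scatter), so little or no real change is anticipated. Compound 3 is estimated at 9000 nM, with an expected range of 3500 nM to 22000 nM.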

Compound 3, half-maximal inhibitory concentration: > 20000 nM
Compound 3: no number, only a limit; the forecaster's own chance of this, stated with the estimate: 5%; at least 2.2-fold (0.34 log units) between middle value and limit.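

Compound 3 in this assay reads as a limit of the assay and not as a number: the limit of > 20000 nM in this assay, at which 1 of the 3 values shown sits. Cyclopropylamino in place of dimethylamino on this saturated chain carbon gives an at least 1.5-fold higher number from compound 2 to compound 3 (0.19 log units; that floor lies within the scatter); the printed floor shows that the read-out does not fall with this change, but it does not establish a shift beyond the scatter. The firmer reading concerns the amine nitrogen, where cyclopropyl in place of 3-(4-methoxyphenyl)propyl gives an at least 7.0-fold higher number from compound 1 to compound 3 (0.84 log units; beyond the scatter), and together with a 4.5-fold higher number from compound 1 to compound 2 (0.66 log units; beyond the scatter) this leaves compound 1 with the lowest number of the three, with neither smaller amine group matching it.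

As far as these compounds go, the true size of the step to compound 3 stays open, since only a floor can be read from a limit, so the order of compound 2 and compound 3 beyond the scatter remains unsettled. From the compounds shown here alone, it also remains open whether the advantage of compound 1 follows the 4-methoxyphenyl group or the propyl chain, a question that a benzylamino group or an unsubstituted phenylpropylamino group at this place would separate.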